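The source may report more compounds than this note shows. Statements on the series, on what has been measured and on what is new or still open speak of the compounds shown alone.

In an ADME assay on the whole organism with Oryza sativa as the target, tested at 0.1 uM (a lower number here means a stronger effect, a higher number a weaker effect of the compound at the concentration tested), compound 2, with the structure `CCOC(=O)c1cccc(NC(=O)N[C@H](C)c2ccccc2)c1`, gives 99%. Among the measured compounds shown here, that is the lowest of the two numbers measured so far, and its nearest neighbour is compound 1, with the structure `Cc1cccc(NC(=O)N[C@H](C)c2ccccc2)c1`, which gives 100% in this assay. The two differ only by a number 1 percentage points lower from compound 1 to compound 2 (within the scatter), so the swap of methyl for ethoxycarbonyl left the read-out essentially unchanged.

Compound 3, with the structure `COc1cccc(NC(=O)N[C@H](C)c2ccccc2)c1`, has not yet been measured. It differs from compound 2 in one place: methoxy in place of ethoxycarbonyl on an aromatic carbon. The ethoxycarbonyl leaves and a methoxy enters on an aromatic carbon of the six-membered carbon ring, meta to a large group. For the measured compounds named here, only one measured step bears on this position, the exchange of methyl for ethoxycarbonyl, and that step stayed within the scatter. Nothing measured therefore points to a shift beyond the scatter when the ethoxycarbonyl gives way to methoxy. For compound 3 a value of 99% is expected, within a range of 88% to 105%, a step of no change at the digits printed from compound 2 to compound 3 (within the scatter) that is itself expected to stay inside the usual scatter.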

Compound 3, a percentage reported as activity, at one concentration (the size of the read-out at that concentration, not a potency): 104%
Compound 3: the middle estimate sits 5 percentage points below what was measured; measured number inside the range.
By their numbers in this assay, from the lowest: compounds 2, 1 and 3 (each within the scatter of the next).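

In this assay this aromatic carbon has now carried a third group, and methoxy in place of ethoxycarbonyl gives a number 5 percentage points higher from compound 2 to compound 3 (within the scatter), so removing a group of 5 heavy atoms with a double bond and putting one of 2 heavy atoms there leaves the read-out where the scatter cannot separate them. Methoxy in place of methyl gives a number 4 percentage points higher from compound 1 to compound 3 (within the scatter), which closes the triangle: all three pairs among methyl, ethoxycarbonyl and methoxy now read alike, so the earlier single step is no longer an isolated result, and no measured group at this place stands apart from the others. Nothing at hand offers a reason for this sameness.

On these data alone, whether an amine, a carboxylic acid, a chlorine atom or a longer chain on this same aromatic carbon would also stay within the scatter remains open. The three compounds also share everything else in the core, so they leave open what a change elsewhere in it would do, and none of them shows which kind of structure would move this read-out beyond the scatter at all.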